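Chloro in place of methyl, with only limits to go on

A few compounds are considered here, and "the series" means these few. Any claim that something is new, unique, unknown or untested is made for them only; others in the source may bear on it.

Measured compounds:
compound 1 `Cc1nnc(SCc2cc(=O)c3cc(Cl)ccc3o2)o1` — > 25000 nM
compound 2 `Nc1nnc(SCc2cc(=O)c3cc(Cl)ccc3o2)s1` — > 25000 nM
compound 3 `Cc1ccc2oc(CSc3nnc(C)s3)cc(=O)c2c1` — > 25000 nM

In a functional assay on SW480 cells (Homo sapiens) for cytotoxicity, read by MTT assay, with a stated time of 72 h (a lower number here means a stronger inhibitor, a higher number a weaker inhibitor), compound 1 gives > 25000 nM, which is a limit of the assay and not a number. Compound 2 gives > 25000 nM, again a limit. Compound 3 gives > 25000 nM, likewise a limit. Among the compounds with values here, all three values sit at the limit of > 25000 nM in this assay, at which 3 of the 3 values shown sit, so no compound can be ranked against another, and the single measured step, a step that the two limits leave unreadable from compound 1 to compound 2, is unreadable.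

Compound 3 therefore stands only at a limit, with no number of its own. Compound 4 `Cc1nnc(SCc2cc(=O)c3cc(Cl)ccc3o2)s1` differs from it by chloro in place of methyl on an aromatic carbon. Within the data shown here, no measured step touches this position: the one step on record, a step that the two limits leave unreadable from compound 1 to compound 2, changes a different part of the shared core and is itself unreadable. Compound 1 and compound 2, which already carry a chloro on that ring, also stop at the limit of > 25000 nM in this assay, at which 3 of the 3 values shown sit.

With nothing beyond limits in hand, compound 4 is expected to remain at the limit as well, with an estimated 25000 nM in this assay, ranging from 10000 nM to 60000 nM. The step of a number no higher from compound 3 to compound 4 (the limit leaves the size open) is expected to be no step beyond the scatter.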

Compound 4, half-maximal inhibitory concentration: > 25000 nM
Compound 4: only a limit was reported; the forecaster's own chance of this, stated with the estimate: 85%; the middle value sits exactly at the limit.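

In this assay compound 4 gives > 25000 nM, which is a limit of the assay and not a number. The steps to compound 4 from compound 1, compound 2 and compound 3 cannot be read, as all four compounds stop at one limit: the limit of > 25000 nM in this assay, at which 4 of the 4 values shown sit.

The compounds shown leave open how strongly any of them acts on these cells, and so whether chloro or methyl, or the choice of group on the sulfur, makes any difference.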